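The source may hold more compounds than are shown below. What is called first, only, known or untested is meant among the compounds shown, and "the series" means these compounds.

Compound 1 `COc1ccc(S(=O)(=O)NC2=NCCN2C(=S)SN2CCn3c2nsc3=S)cc1OC` was tested in a functional assay on KYSE-510 cells (Homo sapiens) for antiproliferative activity, read by crystal violet staining, with a stated time of 96 h; a higher number here means a weaker inhibitor of growth, a lower number a stronger inhibitor of growth. In this assay compound 1 reaches only a limit of the measurement, >= 20000 nM, so no number for it is known. Two close relatives share its core and differ only in the group on the sulfonyl sulfur. Compound 2 `O=S(=O)(NC1=NCCN1C(=S)SN1CCn2c1nsc2=S)c1cccc(OC(F)(F)F)c1` also sits at a limit in this assay, >= 20000 nM. Compound 3 `O=S(=O)(NC1=NCCN1C(=S)SN1CCn2c1nsc2=S)c1ccc(Oc2ccccc2)cc1` likewise gives only a limit in this assay, >= 20000 nM. Taken together, (the limit of >= 20000 nM in this assay, at which 3 of the 3 values shown sit), so every value so far is a boundary rather than a measured number, and compound 1 stands at that boundary with the others.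

Compound 4 `O=S(=O)(NC1=NCCN1C(=S)SN1CCn2c1nsc2=S)c1cccc2ccccc12` has not yet been measured in this assay. It differs from compound 1 in one place: naphthalen-1-yl in place of 3,4-dimethoxyphenyl on a sulfonyl sulfur

No comparison between two measured compounds is available, since all three values are limits. With nothing in the measured set to suggest that a change of the aryl group moves the result, the expectation for the step from compound 1 to compound 4 is one that stays within the usual scatter, which is what a number no higher from compound 1 to compound 4 (the limit leaves the size open) expresses. Compound 4 is therefore expected to give about 20000 nM in this assay, estimated to lie between 8000 nM and 50000 nM, and most likely to be reported again only as a limit.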

Compound 4, concentration for 50% growth inhibition: >= 20000 nM
Compound 4: only a limit was reported; the forecaster's own chance of this, stated with the estimate: 80%; the middle value lies on the limit itself.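

In this assay compound 4 gives >= 20000 nM, which is a limit and not a number. Among the compounds shown here, compound 1 and compound 4 therefore give no step that can be read: the limit of >= 20000 nM in this assay, at which 4 of the 4 values shown sit. The compounds shown leave open whether any group on the sulfonyl sulfur of the shared core would give a measured number in this assay.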